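Swapping the Aryl Group on a Piperidinyl-Piperidine Sulfonamide

The source may hold more compounds than are shown below. What is called first, only, known or untested is meant among the compounds shown, and "the series" means these compounds.

Compound 1 `CC1CCN(C2CCN(S(=O)(=O)c3ccc(C#N)cc3)CC2)CC1` is known in an ADME assay on HCT-116 cells (Homo sapiens) for cytotoxicity, read by CellTiter-Glo, with a stated time of 72 h (a higher number here means a weaker inhibitor, a lower number a stronger inhibitor), only through a limit of the assay: compound 1 gives > 5000 nM. Compound 2 `CC1CCN(C2CCN(S(=O)(=O)c3ccc(-c4ccccc4F)cc3)CC2)CC1` likewise reaches only a limit, and in this assay compound 2 gives > 5000 nM. The step that the two limits leave unreadable from compound 1 to compound 2 therefore cannot be read, because of the limit of > 5000 nM in this assay, at which 2 of the 2 values shown sit. Compound 3 `CC1CCN(C2CCN(S(=O)(=O)c3cccc(Cl)c3)CC2)CC1` differs from compound 1 by 3-chlorophenyl in place of 4-cyanophenyl on a sulfonyl sulfur. Among the measured compounds shown here, no measured step bears readably on this change, so he expects no movement beyond the scatter: compound 3 is estimated at 8000 nM, from 3000 nM to 30000 nM, a step that the limit leaves unreadable from compound 1 to compound 3, most likely again reported only as a limit.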

Compound 3, half-maximal inhibitory concentration: > 5000 nM
Compound 3 gave a limit, no number; the forecaster's own chance of this, stated with the estimate: 80%; the middle value is on the limit's open side.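

Among the compounds shown here, compound 3, like compound 1, gives only a limit, so no step between them can be read, because the result offers no number to compare: the limit of > 5000 nM in this assay, at which 3 of the 3 values shown sit. The compounds shown leave open whether compound 1, compound 2 and compound 3 differ at all in this assay once real values are available.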